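Swapping the piperazine substituent toward a fluorophenyl group

The compounds below may be only part of what the source reports. "The series", "measured", "known", "first", "only" and "open" are said of these compounds alone.

Compound 1, `CCCn1c(=O)[nH]c2nc(-c3ccc(S(=O)(=O)N4CCN(c5ccc(F)cc5)CC4)cc3)[nH]c2c1=O`, in an assay on CHO cells for displacement of a labelled ligand from adenosine receptor A3 (Homo sapiens), read by scintillation counting, with a stated time of 45 min, tested at 1 uM, in the presence of a further agent that is not named here; on this read-out higher numbers stand for more inhibition at the one concentration tested (going by the name of the read-out) and lower numbers for less inhibition: 38%
Compound 2, `CCCn1c(=O)[nH]c2nc(-c3ccc(S(=O)(=O)N4CCN(c5ccccc5C)CC4)cc3)[nH]c2c1=O`, in this assay: 25%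
Compound 3, `CCCn1c(=O)[nH]c2nc(-c3ccc(S(=O)(=O)N4CCN(C)CC4)cc3)[nH]c2c1=O`, in this assay: 7%

Compound 3 stands lowest of the three numbers in this assay. Its nearest neighbour is compound 2, and the step there is a number 18 percentage points lower from compound 2 to compound 3 (beyond the scatter); its furthest is compound 1, where the step is a number 31 percentage points lower from compound 1 to compound 3 (beyond the scatter). Between the two aryl-bearing compounds the step is a number 13 percentage points lower from compound 1 to compound 2 (beyond the scatter).

Compound 4, `CCCn1c(=O)[nH]c2nc(-c3ccc(S(=O)(=O)N4CCN(c5cccc(F)c5)CC4)cc3)[nH]c2c1=O`, has not yet been measured in this assay. It differs from compound 3 by 3-fluorophenyl in place of methyl on an amine nitrogen in a ring.

For the measured compounds named here, two measured steps bear on this change, both run in the opposite direction: a number 31 percentage points lower from compound 1 to compound 3 (beyond the scatter) and a number 18 percentage points lower from compound 2 to compound 3 (beyond the scatter). Each replaced an aryl group on that ring nitrogen with methyl and each lowered the number beyond the scatter, the fluorophenyl case more so. Going back from methyl to a fluorophenyl group is therefore expected to raise the number in this assay by a step comparable in size to those, and the estimated step is a number 25 percentage points higher from compound 3 to compound 4 (beyond the scatter). Compound 4 is thus expected to give about 32%, within a range of 15% to 50%.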

Compound 4, a percentage reported as inhibition, at one concentration (the size of the read-out at that concentration, not a potency): 44%
For compound 4 the middle estimate is 12 percentage points below the measured one; the measured number falls inside the stated range.
By their numbers in this assay, from the lowest: compound 3; then compound 2; then compounds 1 and 4 (each within the scatter of the next).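

For the compounds shown here, with 3-fluorophenyl on the amine nitrogen in a ring, this assay gives a number 37 percentage points higher from compound 3 to compound 4 (beyond the scatter) and so shows directly, in the forward direction, the gain that the earlier steps showed only as losses on going to methyl; all three aryl-bearing compounds now stand beyond the scatter above compound 3. The step of a number 6 percentage points higher from compound 1 to compound 4 (within the scatter) adds that 3-fluorophenyl and 4-fluorophenyl cannot be told apart on this read-out, so a fluorophenyl group of either kind gives much the same number at the one concentration tested. The step of a number 19 percentage points higher from compound 2 to compound 4 (beyond the scatter) then places 3-fluorophenyl beyond the scatter above 2-methylphenyl, as 4-fluorophenyl already was, so the aryl groups on this nitrogen do not all read alike.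

Nothing given here accounts for these steps or explains why the aryl groups differ from methyl or from each other. From the compounds shown here alone, it also stays open how a 3-methylphenyl, a 2-fluorophenyl or a benzyl group on this nitrogen would read, which would show whether the lower number of compound 2 goes with its methyl group or with where that group sits.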